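The compounds below may be only part of what the source reports. "The series", "measured", "known", "first", "only" and "open" are said of these compounds alone.

Measured in an ADME assay on microsomes from liver (Homo sapiens) for metabolic stability, with a stated time of 30 min, tested at 1 uM; on this read-out lower numbers stand for a shorter-lived compound and higher numbers for a longer-lived compound:
Compound 1 `COc1ccc2[nH]c(C(=O)N3CC(=O)N(Cc4ccccc4)[C@@H](CCc4ccccc4)C3)cc2c1` gives 0.167 h.
Compound 2 `COc1ccc2[nH]c(C(=O)N3CC(=O)N(Cc4ccccc4)[C@@H](COc4ccccc4)C3)cc2c1` gives 0.65 h.
Compound 3 `COc1ccc2[nH]c(C(=O)N3CC(=O)N(Cc4ccccc4)[C@@H](CN4CCCCC4)C3)cc2c1` gives 0.283 h.

Compound 3 stands second highest of the three in this assay; its nearest neighbour is compound 1, with a 1.7-fold higher number from compound 1 to compound 3 (0.23 log units; within the scatter), and its furthest is compound 2, with a 2.3-fold lower number from compound 2 to compound 3 (0.36 log units; beyond the scatter). Compound 4 `COc1ccc2[nH]c(C(=O)N3CC(=O)N(Cc4ccccc4)[C@@H](CN4CCC5(CC4)CC5)C3)cc2c1` differs from compound 3 only at the piperidin-1-yl: a group of 8 heavy atoms (7 carbon, 1 nitrogen; one three-membered non-aromatic ring of carbon only, one six-membered non-aromatic ring with 1 hetero atom) in place of a group of 6 heavy atoms (5 carbon, 1 nitrogen; one six-membered non-aromatic ring with 1 hetero atom), on a saturated chain carbon bound to a saturated ring carbon. Among the compounds with values here, no measured step enlarges this group in the same way; the two steps touching this place, a 1.7-fold higher number from compound 1 to compound 3 (0.23 log units; within the scatter) and a 2.3-fold lower number from compound 2 to compound 3 (0.36 log units; beyond the scatter), exchange whole groups and were modest or within the scatter. A step of a 1.1-fold lower number from compound 3 to compound 4 (0.05 log units; within the scatter) is therefore expected, with no direction beyond the scatter supported. Compound 4 is estimated at 0.25 h, range 0.12 h to 0.55 h.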

Compound 4, half-life: 0.867 h
Compound 4: middle estimate off by 3.5-fold (0.54 log units), on the low side; the whole stated range lies below it.
By their numbers in this assay, from the lowest: compounds 1 and 3 (each within the scatter of the next); then compounds 2 and 4 (each within the scatter of the next).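

At this place, on a saturated chain carbon bound to a saturated ring carbon, adding a three-membered carbon ring to the piperidin-1-yl moves the half-life in this assay beyond the scatter (a 3.1-fold higher number from compound 3 to compound 4 (0.49 log units; beyond the scatter)), so an enlargement of the group registers, not only an exchange of whole groups. The entering group sits level with phenoxy (a 1.3-fold higher number from compound 2 to compound 4 (0.13 log units; within the scatter)) and clear of benzyl (a 5.2-fold higher number from compound 1 to compound 4 (0.72 log units; beyond the scatter)). No measurement shown here accounts for this step.

Still open, going by these compounds, is whether the three-membered ring itself or the larger group as a whole matters. On these data alone, how a morpholine or a dimethylpiperidine would read at this place also remains unknown.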